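Removing the Dimethylamino Group: What Lipophilicity to Expect

This account rests on a few compounds, and the source may have more. Where it says the series, first, only, none or still open, it means among the compounds named here.

Measured compounds:
- compound 1 `Cc1ccc(/C=C2\CCC/C(=C\c3ccc([N+](=O)[O-])cc3)C2=O)cc1` gives 5.08 in a physicochemical assay for lipophilicity; on this read-out lower numbers stand for lower lipophilicity and higher numbers for higher lipophilicity
- compound 2 `O=C1/C(=C/c2ccc(Cl)cc2)CCC/C1=C\c1ccc([N+](=O)[O-])cc1` gives 5.08 in this assay
- compound 3 `CN(C)c1ccc(/C=C2\CCC/C(=C\c3ccc([N+](=O)[O-])cc3)C2=O)cc1` gives 5.08 in this assay

Compound 3 stands level with compounds 1 and 2 in this assay; all three share the same core and differ only in one group on an aromatic carbon. The measured steps among them, no change at the digits printed from compound 1 to compound 2 (within the scatter), no change at the digits printed from compound 1 to compound 3 (within the scatter) and no change at the digits printed from compound 2 to compound 3 (within the scatter), show that exchanging methyl, chloro and dimethylamino at this place left the read-out unchanged within the scatter.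

Compound 4 `O=C1/C(=C/c2ccccc2)CCC/C1=C\c1ccc([N+](=O)[O-])cc1` is the next member of this series. It differs from compound 3 in one place: hydrogen in place of dimethylamino on an aromatic carbon. This exchange is of the same kind as the three measured steps, which all bear on it and were all without effect beyond the scatter, so no step beyond the scatter is expected here either, in either direction. The expected step from compound 3 to compound 4 is therefore no change at the digits printed from compound 3 to compound 4 (within the scatter). For compound 4 the estimate in this assay is 5.08, with a range from 4.7 to 5.45.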

Compound 4, partition coefficient: 5.08
Beside the measured number, compound 4's estimate shows no gap at the digits printed; the measured number falls inside the stated range.
By their numbers in this assay, from the lowest: compounds 1, 2, 3 and 4 (each within the scatter of the next).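

Compound 4 carries no group at all at this place on the aromatic carbon, so it tests removal rather than one more exchange, and in this assay the result is no change at the digits printed from compound 3 to compound 4 (within the scatter) even with dimethylamino gone. The comparisons with the other two read no change at the digits printed from compound 2 to compound 4 (within the scatter) and no change at the digits printed from compound 1 to compound 4 (within the scatter) and thus place plain hydrogen level with methyl, chloro and dimethylamino in this series. No measurement at hand offers a reason for this flat result.

The compounds shown leave open whether a carboxylic acid or a longer alkyl chain at this place would also leave the read-out level. They also leave open what exchanges elsewhere on the shared core would do, since all four compounds differ at this one place only.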